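Dichlorophenyl swap on the sulfonamide nitrogen

This account rests on a few compounds, and the source may have more. Where it says the series, first, only, none or still open, it means among the compounds named here.

Measured in a functional assay on J774 cells (Mus musculus) for cytotoxicity (a lower number here means a stronger inhibitor, a higher number a weaker inhibitor), so far
- compound 1 `CCCN(CCC)c1c([N+](=O)[O-])cc(S(=O)(=O)Nc2ccc(C)cc2)cc1[N+](=O)[O-]` gives 11000 nM
- compound 2 `CCCN(CCC)c1c([N+](=O)[O-])cc(S(=O)(=O)Nc2cccc(OC)c2)cc1[N+](=O)[O-]` gives 25000 nM
- compound 3 `CCCN(CCC)c1c([N+](=O)[O-])cc(S(=O)(=O)Nc2ccc(Cl)c(Cl)c2)cc1[N+](=O)[O-]` gives 7200 nM

Compound 1 cannot be separated from compound 3 (a 1.5-fold lower number from compound 1 to compound 3 (0.18 log units; within the scatter)), while compound 2 stands higher (a 2.3-fold higher number from compound 1 to compound 2 (0.36 log units; beyond the scatter)). The next compound is compound 4 `CCCN(CCC)c1c([N+](=O)[O-])cc(S(=O)(=O)Nc2cc(Cl)cc(Cl)c2)cc1[N+](=O)[O-]`, and its change from compound 1 is 3,5-dichlorophenyl in place of 4-methylphenyl on a sulfonamide nitrogen on the shared core. Within the data shown here, no measured compound carries the 3,5-dichlorophenyl group, so the nearest guide is the 3,4-dichlorophenyl of compound 3. That group gave a step within the scatter from compound 1 and a modest one from the 3-methoxyphenyl of compound 2 (a 3.5-fold lower number from compound 2 to compound 3 (0.54 log units; beyond the scatter)). All three measured steps are small, so only a small move in this assay is expected, probably downward and not beyond the scatter. The expected change is small (a 1.6-fold lower number from compound 1 to compound 4 (0.20 log units; within the scatter)). The value of compound 4 is estimated at 7000 nM (expected range 3000 nM to 16000 nM).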

Compound 4, half-maximal inhibitory concentration: 5100 nM
For compound 4 the middle estimate is 1.4-fold (0.14 log units) above the measured one, and the stated range covers the measured number.
By their numbers in this assay, from the lowest: compounds 4, 3 and 1 (each within the scatter of the next, the first and the last beyond it); then compound 2.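

Replacing 4-methylphenyl with 3,5-dichlorophenyl on a sulfonamide nitrogen gives a step beyond the scatter in this assay (a 2.2-fold lower number from compound 1 to compound 4 (0.33 log units; beyond the scatter)), which the 3,4-dichlorophenyl group did not give from the same starting point. The two dichlorophenyl groups themselves cannot be separated (a 1.4-fold lower number from compound 3 to compound 4 (0.15 log units; within the scatter)), so the placing of the two chlorines makes no readable difference among the compounds shown, while the 3-methoxyphenyl group remains clearly apart, with the largest step in the set so far (a 4.9-fold lower number from compound 2 to compound 4 (0.69 log units; beyond the scatter)). Nothing available bears on why the number moves with these groups.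

From the compounds shown here alone, whether a single chlorine, a trifluoromethyl or a carboxylic acid on the phenyl ring would move the number further remains open. So does the effect of an amine or a longer chain in place of the aryl group on the sulfonamide nitrogen.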